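Tolyl for phenyl sulfonyl on a cytotoxicity series

The compounds below may be only part of what the source reports. "The series", "measured", "known", "first", "only" and "open" are said of these compounds alone.

Compound 1, `O=C1/C(=C/c2cccnc2)CN(S(=O)(=O)c2ccccc2)C/C1=C\c1ccccc1F`, gives 8210 nM in a functional assay on HepG2 cells (Homo sapiens) for cytotoxicity, read by MTT assay, with a stated time of 24 h; a lower number here means a stronger inhibitor, a higher number a weaker inhibitor. Compound 2, `Cc1ccc(S(=O)(=O)N2C/C(=C\c3cccnc3)C(=O)/C(=C/c3ccccc3F)C2)cc1`, differs from it by methyl in place of hydrogen on an aromatic carbon and in this assay gives 4200 nM; the step of a 2.0-fold lower number from compound 1 to compound 2 (0.29 log units; within the scatter) is recorded as within the scatter. Compound 3, `O=C1/C(=C/c2ccncc2)CN(S(=O)(=O)c2ccccc2)C/C1=C\c1ccccc1C(F)(F)F`, gives 7020 nM in this assay. The difference between the core of compound 3 and the core of compound 1 is not broken down here; the two values stand within the scatter of each other, so nothing is to be ordered between them.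

Compound 4, `Cc1ccc(S(=O)(=O)N2C/C(=C\c3ccncc3)C(=O)/C(=C/c3ccccc3C(F)(F)F)C2)cc1`, has not yet been measured in this assay. It differs from compound 3 by methyl in place of hydrogen on an aromatic carbon, the same change as that from compound 1 to compound 2, placed on the same sort of ring in both pairs. Within the data shown here, the only precedent is the step from compound 1 to compound 2, a change within the scatter, so a step of similar size is expected, a 1.7-fold lower number from compound 3 to compound 4 (0.22 log units; within the scatter), resting on a 2.0-fold lower number from compound 1 to compound 2 (0.29 log units; within the scatter). Compound 4 is therefore estimated at 4200 nM in this assay, expected to fall between 2000 nM and 9000 nM.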

Compound 4, half-maximal inhibitory concentration: 4640 nM
Beside the measured number, compound 4's estimate is 1.1-fold (0.04 log units) below it; the measured number falls inside the stated range.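

In this assay, the change from phenylsulfonyl to (4-methylphenyl)sulfonyl on the second core gives a 1.5-fold lower number from compound 3 to compound 4 (0.18 log units; within the scatter). Each step lies within the scatter, so neither pair establishes that the methyl lowers the number on its own core, and two pairs give no rule for cores beyond these two. What can be said is limited to this: the change behaves alike on the two cores, with no detectable dependence on the core, as the two steps do not differ: the same change on two cores in this assay, a 2.0-fold lower number (0.29 log units; within the scatter) from compound 1 to compound 2 and a 1.5-fold lower number (0.18 log units; within the scatter) from compound 3 to compound 4, 1.3-fold (0.11 log units) apart, within the scatter of two such steps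

Open, from the compounds shown here alone, is whether any replacement at this position moves the number beyond the scatter, for example a methoxy group, a chlorine atom, an amine, a carboxylic acid or a longer chain in place of the methyl. Also open, going by these compounds, is how the same change behaves on cores other than those of compound 1 and compound 3.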